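From Difluorophenyl to Dichlorophenyl on the Sulfonyl Sulfur

This account rests on a few compounds, and the source may have more. Where it says the series, first, only, none or still open, it means among the compounds named here.

In an ADME assay on HCT-116 cells (Homo sapiens) for cytotoxicity, read by CellTiter-Glo, with a stated time of 72 h (on this read-out lower numbers stand for stronger inhibition and higher numbers for weaker inhibition), compound 1 (`Cc1ccc(S(=O)(=O)N2CCC(N3CCC(C)CC3)CC2)cc1C`) gives > 5000 nM as a limit of the assay. From the compounds shown here alone, compound 2 (`CC1CCN(C2CCN(S(=O)(=O)c3ccc(F)cc3F)CC2)CC1`) likewise gives > 5000 nM as a limit, so its true value is unknown. Compound 3 (`CC1CCN(C2CCN(S(=O)(=O)c3ccc(Cl)cc3Cl)CC2)CC1`) has 2,4-dichlorophenyl in place of 2,4-difluorophenyl on a sulfonyl sulfur. Going by the values given here, the only measured step at that place, a step that the two limits leave unreadable from compound 1 to compound 2, has no readable size, and the evidence amounts to the limit of > 5000 nM in this assay, at which 2 of the 2 values shown sit. No step beyond the scatter is therefore expected in this assay, in either direction. The estimated step is a step that the limit leaves unreadable from compound 2 to compound 3 in size. Compound 3 is estimated at 6000 nM, with an expected range from 2500 nM to 15000 nM, and will probably be reported only as a limit.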

Compound 3, half-maximal inhibitory concentration: > 5000 nM
Compound 3 gave a limit, no number (the forecaster's own chance of this, stated with the estimate: 85%); the middle value lies beyond the limit too.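

Compound 1, compound 2 and compound 3 all stop at the same limit, so no step among them can be read: the limit of > 5000 nM in this assay, at which 3 of the 3 values shown sit.

From the compounds shown here alone, whether the group on the sulfonyl sulfur changes the true values beyond that limit stays open.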